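Series notes: moving the amino group of compound 2

The source may report more compounds than this note shows. Statements on the series, on what has been measured and on what is new or still open speak of the compounds shown alone.

Compound 2 `Nc1cccc(-c2cnc(C(=O)CCCCCCc3ccccc3)o2)c1` gives 19 nM in an assay (Rattus norvegicus) for inhibition of Fatty-acid amide hydrolase 1 (Homo sapiens) (on this read-out higher numbers stand for weaker inhibition and lower numbers for stronger inhibition), the second highest of the three numbers measured. Compound 3 `COC(=O)c1cccc(-c2cnc(C(=O)CCCCCCc3ccccc3)o2)c1` gives 12 nM in this assay; the change a 1.6-fold lower number from compound 2 to compound 3 (0.20 log units; within the scatter) stays within the scatter. Compound 1 `O=C(CCCCCCc1ccccc1)c1ncc(-c2ccccc2C(=O)C(F)(F)F)o1` gives 5000 nM in this assay, a far higher number, but it differs from compound 2 in more than one place. The unmeasured compound 4 `Nc1ccc(-c2cnc(C(=O)CCCCCCc3ccccc3)o2)cc1` differs from compound 2 by 4-aminophenyl in place of 3-aminophenyl on an aromatic carbon. Among the measured compounds shown here, no measured step shifts the amino group from one ring carbon to another; the single measured step swaps the group itself and lies within the scatter. Compound 4 is therefore expected to sit close to compound 2, a step of a 1.3-fold higher number from compound 2 to compound 4 (0.12 log units; within the scatter) that is expected to stay within the scatter. The estimate for compound 4 is 25 nM, ranging from 8 nM to 80 nM.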

Compound 4, inhibition constant: 90 nM
The estimate for compound 4 lay 3.6-fold (0.56 log units) below the measured number; measured number outside the range, above it.
By their numbers in this assay, from the lowest: compounds 3 and 2 (each within the scatter of the next); then compound 4; then compound 1.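

In this assay the change from 3-aminophenyl to 4-aminophenyl gives a 4.7-fold higher number from compound 2 to compound 4 (0.68 log units; beyond the scatter), although both groups have the same atoms and the same counts. The earlier step on this phenyl ring, a 1.6-fold lower number from compound 2 to compound 3 (0.20 log units; within the scatter), stayed within the scatter, so the place of the amino group on the ring registers where exchanging amino for methoxycarbonyl did not. Nothing available explains this shift.

On these data alone, it remains open whether methoxycarbonyl, a carboxylic acid or a hydroxyl group would respond to the same move as the amino group does.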